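The compounds below may be only part of what the source reports. "The series", "measured", "known", "first", "only" and "open" are said of these compounds alone.

Measured so far in a functional assay for inhibition of Nucleic Acid, read by thymidine incorporation, tested at 5 uM; on this read-out lower numbers stand for a weaker effect and higher numbers for a stronger effect at the one concentration tested:

- compound 1 `Nc1ncnc2c1ncn2[C@@H]1O[C@H](CO)C[C@H]1OP(=O)(O)OC[C@H]1O[C@@H](n2cnc3c(N)ncnc32)C[C@@H]1O`: 0%
- compound 2 `Nc1ncnc2c1ncn2[C@H]1C[C@H](OP(=O)(O)OC[C@H]2O[C@@H](n3cnc4c(N)ncnc43)C[C@@H]2O)[C@@H](CO)O1`: 13%

Of these two numbers, compound 2 stands highest. Its nearest neighbour is compound 1, whose read-out is lower by a margin beyond the usual scatter, so the two compounds are clearly set apart in this assay. Within the data shown here, no pair of measured compounds differs in only one place, so no single structural change has yet been tied to a change in read-out.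

Compound 3 `Nc1ncnc2c1ncn2[C@H]1C[C@H](OP(=O)(O)OC[C@H]2O[C@@H](n3cnc4c(N)ncnc43)C[C@@H]2O)[C@@H](COP(=O)(O)O)O1` has not been measured. It differs from compound 2 in one place: a group of 4 heavy atoms (3 oxygen, 1 phosphorus; no ring) in place of a hydrogen atom, on an oxygen on a saturated carbon. With nothing measured to anchor such a change, the step is expected to be small, and it is estimated as a number 2 percentage points higher from compound 2 to compound 3 (within the scatter), which would stay within the usual scatter. Compound 3 is therefore estimated at 15%, with a likely range from 0% to 40%.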

Compound 3, a percentage reported as inhibition, at one concentration (the size of the read-out at that concentration, not a potency): 3%
Estimate against measurement, compound 3: 12 percentage points above; measured number inside the range.
By their numbers in this assay, from the lowest: compounds 1, 3 and 2 (each within the scatter of the next, the first and the last beyond it).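

In this assay, among these compounds, a group of 4 heavy atoms (3 oxygen, 1 phosphorus; no ring) in place of a hydrogen atom, on an oxygen on a saturated carbon, gives a number 10 percentage points lower from compound 2 to compound 3 (within the scatter), the first step in this set that can be tied to a single structural change. Because that step lies within the usual scatter, the read-outs of these two compounds cannot be told apart, so this oxygen can carry the added group with no clear effect on the result. Nothing measured here explains this outcome.

The compounds shown leave open whether a different group on this oxygen, such as a methyl or an amine, would produce a step beyond the scatter. They also leave open how this change would appear at other concentrations, since a single-concentration read-out is not a potency.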